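This account rests on a few compounds, and the source may have more. Where it says the series, first, only, none or still open, it means among the compounds named here.

Values measured so far in a functional assay on SGC-7901 cells (Homo sapiens) for antiproliferative activity, read by MTT assay, with a stated time of 72 h (on this read-out lower numbers stand for stronger inhibition and higher numbers for weaker inhibition), are these:

- Compound 1 `COc1cc(-n2cnc3ccc(-c4ccccc4)cc32)cc(OC)c1OC` gives 290 nM here
- Compound 2 `COc1cc(-n2cnc3ccc(-c4cccc(Cl)c4)cc32)cc(OC)c1OC` gives 1490 nM here

Compound 2 holds the higher of the two numbers, so it is the weaker inhibitor of the pair. Compound 3 `COc1cc(-n2cnc3ccc(-c4ccc(Cl)cc4)cc32)cc(OC)c1OC` has 4-chlorophenyl in place of 3-chlorophenyl on an aromatic carbon. Among the compounds with values here, one measured step bears on this, the modest 5.1-fold higher number from compound 1 to compound 2 (0.71 log units; beyond the scatter) seen with chloro in place of hydrogen on an aromatic carbon. That step adds the chloro and does not relocate it, so the data do not show what the new placement does. Compound 3 keeps the chloro, so compound 2 at 1490 nM is the closer guide, and no change beyond the scatter is expected in this assay for this pair. The expected step is a 1.4-fold lower number from compound 2 to compound 3 (0.13 log units; within the scatter) on this estimate. For compound 3 the estimated value is 1100 nM within an expected range from 400 nM to 3000 nM in all.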

Compound 3, half-maximal inhibitory concentration: 1270 nM
The estimate for compound 3 lay 1.2-fold (0.06 log units) below the measured number, and the stated range covers the measured number.
By their numbers in this assay, from the lowest: compound 1; then compounds 3 and 2 (each within the scatter of the next).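

In this assay, moving the chloro from the 3-chlorophenyl to the 4-chlorophenyl arrangement gives a 1.2-fold lower number from compound 2 to compound 3 (0.07 log units; within the scatter) on this position, so the two placements cannot be told apart on this read-out. Against hydrogen on that carbon, the chloro in its new placement still shows a 4.4-fold higher number from compound 1 to compound 3 (0.64 log units; beyond the scatter) and so, in the two chlorinated compounds shown, the higher number goes with having the chloro at either place rather than with which place it holds. No evidence at hand gives a reason for this result.

On these data alone, whether an amine or a carboxylic acid on this ring would stay close to compound 1 at 290 nM remains open. Also open, as far as these compounds go, is whether the same indifference to placement would hold for a group other than chloro.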